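The compounds below may be only part of what the source reports. "The series", "measured", "known", "first", "only" and "open" are said of these compounds alone.

Measured so far:
compound 1 `Cc1c(/N=C/c2ccc(N(C)C)cc2)c(=O)n(-c2ccccc2)n1C` — in a functional assay on DLD-1 cells (Homo sapiens) for cytotoxicity, read by MTT assay, with a stated time of 72 h (a lower number here means a stronger inhibitor, a higher number a weaker inhibitor), compound 1 gives 871000000 nM
compound 2 `Cc1c(/N=C/c2ccccc2Cl)c(=O)n(-c2ccccc2)n1C` — compound 2 gives 417000000 nM
compound 3 `COc1cc(/C=N/c2c(C)n(C)n(-c3ccccc3)c2=O)ccc1O` — compound 3 gives 759000000 nM

Compound 2 has the lowest of these three numbers in this assay. Its gap to compound 3 lies within the scatter, so the two cannot be told apart, while its gap to compound 1 lies beyond the scatter. Compound 4 `Cc1c(/N=C/c2cccc(Cl)c2)c(=O)n(-c2ccccc2)n1C` has not yet been measured. It differs from compound 2 in one place: 3-chlorophenyl in place of 2-chlorophenyl on a carbon with a double bond to nitrogen. Within the data shown here, no measured pair shows what exchanging these two chlorophenyl groups does, so nothing here points to a step in either direction, and the expectation is a change no larger than the scatter. Compound 4 is expected to give about 450000000 nM in this assay, between 200000000 nM and 1000000000 nM. The expected step of a 1.1-fold higher number from compound 2 to compound 4 (0.03 log units; within the scatter) is accordingly small.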

Compound 4, half-maximal inhibitory concentration: 724000000 nM
The estimate for compound 4 lay 1.6-fold (0.21 log units) below the measured number, within the range that was stated.
By their numbers in this assay, from the lowest: compounds 2, 4, 3 and 1 (each within the scatter of the next, the first and the last beyond it).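

Among these compounds, exchanging 2-chlorophenyl for 3-chlorophenyl on a carbon with a double bond to nitrogen gives the first one-place comparison in this assay, a step of a 1.7-fold higher number from compound 2 to compound 4 (0.24 log units; within the scatter). The two compounds therefore cannot be told apart, so moving the chlorine in this way has no readable effect on the number in this assay. Nothing available explains the size of this step.

Still open, from the compounds shown here alone, is what an amine or a carboxylic acid in place of the chlorine would give in this assay.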